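The source may hold more compounds than are shown below. What is called first, only, known or untested is meant among the compounds shown, and "the series" means these compounds.

Measured compounds in this set:

compound 1, `CCCCCSc1nc(C(F)(F)F)ccc1CNC(=O)C(C)c1ccc(NS(C)(=O)=O)c(F)c1`, 2.5 nM
compound 2, `COC(=O)CCSc1nc(C(F)(F)F)ccc1CNC(=O)C(C)c1ccc(NS(C)(=O)=O)c(F)c1`, 48.2 nM
compound 3, `CC(C(=O)NCc1ccc(C(F)(F)F)nc1SCCC(=O)N1CCCC1)c1ccc(NS(C)(=O)=O)c(F)c1`, 85 nM

In an assay on CHO-K1 cells for antagonist activity at transient receptor potential cation channel subfamily V member 1 (Homo sapiens), read by FLIPR (a higher number here means a weaker inhibitor, a lower number a stronger inhibitor), compound 3 gives the highest number of the three. Its nearest neighbour is compound 2, and the step of a 1.8-fold higher number from compound 2 to compound 3 (0.25 log units; within the scatter) is within the scatter, so the two cannot be ordered. Compound 1 stands far off: the step of a 34-fold higher number from compound 1 to compound 3 (1.53 log units; beyond the scatter) is large.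

Compound 4 is `CC(C(=O)NCc1ccc(C(F)(F)F)nc1SCc1ccc(Cl)cc1)c1ccc(NS(C)(=O)=O)c(F)c1`. It differs from compound 3 in one place: 4-chlorophenyl in place of ((pyrrolidin-1-yl)carbonyl)methyl on a saturated chain carbon bound to a sulfur. The measured steps that bear on this change are those from compound 1, where propyl sits two bonds along the chain from the sulfur. Replacing that propyl by a carbonyl-bearing group raised the number a great deal in both cases: a 19-fold higher number from compound 1 to compound 2 (1.29 log units; beyond the scatter) and a 34-fold higher number from compound 1 to compound 3 (1.53 log units; beyond the scatter). Compound 4 removes the carbonyl-bearing group again and puts in its place a 4-chlorophenyl, which, like the propyl of compound 1, carries no carbonyl. The step from compound 3 to compound 4 is therefore expected to be large and downward, in the direction of compound 1, though a benzyl-type group at this position has not been measured, so the return need not be complete. The estimate is an 11-fold lower number from compound 3 to compound 4 (1.03 log units; beyond the scatter).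

Compound 4 is expected to give about 8 nM in this assay, within a range from 2 nM to 40 nM.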

Compound 4, inhibition constant: 8.7 nM
Compound 4: middle estimate off by 1.1-fold (0.04 log units), on the low side; low and high end bracket the measured number.
By their numbers in this assay, from the lowest: compound 1; then compound 4; then compounds 2 and 3 (each within the scatter of the next).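

In this assay, a 4-chlorobenzyl group on the sulfur brings the number well down from those of the two carbonyl-bearing chains (a 9.8-fold lower number from compound 3 to compound 4 (0.99 log units; beyond the scatter); a 5.5-fold lower number from compound 2 to compound 4 (0.74 log units; beyond the scatter)), so this position is shown to accept an aromatic ring, whereas the earlier compounds carried only open chains. The return is only partial, however (a 3.5-fold higher number from compound 1 to compound 4 (0.54 log units; beyond the scatter)), and this step is beyond the scatter, so the 4-chlorobenzyl group does not match the plain alkyl chain of compound 1. Among these four compounds, the two without a carbonyl in the sulfur substituent give the lower numbers and the two with one give the higher numbers, and no compound shown goes against this.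

Nothing available explains why the number moves with these groups. On these data alone, what a plain benzyl, a 4-fluorobenzyl or a 2-phenylethyl group on the sulfur would give remains open, which leaves the part played by the chlorine undecided, and the same holds for a carboxylic acid or an amine at the end of the chain.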